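This account rests on a few compounds, and the source may have more. Where it says the series, first, only, none or still open, it means among the compounds named here.

Of the compounds shown here, three sharing one core have been tested in a functional assay on cells for antagonist activity at prostaglandin D2 receptor 2 (Homo sapiens), read by flow cytometry, with a stated time of 10 min; on this read-out lower numbers stand for stronger inhibition and higher numbers for weaker inhibition. Compound 1 `COCCN(C)S(=O)(=O)c1ccc(C)c(C#Cc2cc(Cl)ccc2OCC(=O)O)c1` carries a (2-methoxyethyl)(methyl)amino group on its sulfonyl sulfur and gives 77 nM. Compound 2 `CS(=O)(=O)c1ccc(F)c(C#Cc2cc(Cl)ccc2OCC(=O)O)c1` carries a fluoro group on an aromatic carbon of the ring that also bears the sulfonyl group, and gives 95 nM. Compound 3 `Cc1ccc(S(C)(=O)=O)cc1C#Cc1cc(Cl)ccc1OCC(=O)O` has a methyl group in both of those places and gives 64 nM. Compound 3 shows the lowest number of the three, but both a 1.2-fold lower number from compound 1 to compound 3 (0.08 log units; within the scatter) and a 1.5-fold lower number from compound 2 to compound 3 (0.17 log units; within the scatter) lie within the scatter of this assay, so none of the three can be set apart from the others.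

Compound 4 `CS(=O)(=O)c1ccc(Cl)c(C#Cc2cc(Cl)ccc2OCC(=O)O)c1` differs from compound 3 in a single point: chloro in place of methyl on an aromatic carbon. For the measured compounds named here, the only measured step at this same aromatic carbon is the exchange of fluoro for methyl, a 1.5-fold lower number from compound 2 to compound 3 (0.17 log units; within the scatter), which did not move the number beyond the scatter. No chloro group at this position has been measured, so the expectation rests on that one step alone: a small change in this assay, in no certain direction, is expected, which for compound 4 means an estimated 75 nM with a range from 35 nM to 160 nM. Expressed as a step, the expectation is a 1.2-fold higher number from compound 3 to compound 4 (0.07 log units; within the scatter).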

Compound 4, half-maximal inhibitory concentration: 26 nM
For compound 4 the middle estimate is 2.9-fold (0.46 log units) above the measured one; measured number outside the range, below it.
By their numbers in this assay, from the lowest: compound 4; then compounds 3, 1 and 2 (each within the scatter of the next).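

For the compounds shown here, the position is more sensitive than the earlier compounds suggested. In this assay, chloro in place of methyl gives a 2.5-fold lower number from compound 3 to compound 4 (0.39 log units; beyond the scatter) and chloro in place of fluoro gives a 3.7-fold lower number from compound 2 to compound 4 (0.56 log units; beyond the scatter) on the same aromatic carbon, para to a methylsulfonyl group, whereas methyl and fluoro could not be told apart there. Chloro is therefore the first group at this carbon to stand clear of the scatter, even though chloro and methyl each count as a single heavy atom, and nothing shown here explains the difference.

Going by these compounds, it remains open how other groups at this carbon, such as bromo, trifluoromethyl, methoxy or a nitrile, or plain hydrogen, would compare with chloro. Compound 1 differs from compound 4 in two places, so it is also unknown whether chloro would bring a similar change in a compound carrying the (2-methoxyethyl)(methyl)amino group on its sulfonyl sulfur.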